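A few compounds are considered here, and "the series" means these few. Any claim that something is new, unique, unknown or untested is made for them only; others in the source may bear on it.

Measured compounds:
- compound 1, `CC(C)CCN(CCC(C)C)c1ccc(C(=O)N2CCc3ccc(OS(N)(=O)=O)cc3C2)cc1`: 47%
- compound 2, `CN(C)CCCN(Cc1ccccc1)c1ccc(C(=O)N2CCc3ccc(OS(N)(=O)=O)cc3C2)cc1`: 16.2%
- compound 3, `NS(=O)(=O)Oc1ccc2c(c1)CN(C(=O)c1cccc(N3CCC(Cc4ccccc4)CC3)c1)CC2`: 1.4%

In an assay on HEK293 cells for inhibition of Steryl-sulfatase (Homo sapiens), tested at 0.1 uM (on this read-out lower numbers stand for a weaker effect and higher numbers for a stronger effect at the one concentration tested), compound 1 gives 47%, the highest of the three numbers. Compound 2 gives 16.2%, which lies beyond the scatter below compound 1, and compound 3 gives 1.4%, further still below it. All three share the same core with a sulfamate group; they differ in the amine group carried on the outer ring.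

Compound 4, `CCN(Cc1cccc(Br)c1)c1ccc(C(=O)N2CCc3ccc(OS(N)(=O)=O)cc3C2)cc1`, has not yet been tested. It differs from compound 1 in one place: (3-bromobenzyl)(ethyl)amino in place of diisopentylamino on an aromatic carbon. Within the data shown here, no measured pair shows exactly this exchange, so the size of the step can only be guessed. Compound 2, which also carries a benzyl group, gives 16.2%, a much lower number than compound 1, so a decrease in this assay beyond the scatter seems the more likely direction, though compound 2 also carries a different second chain and the comparison is loose. The expected step from compound 1 to compound 4 is a number 17 percentage points lower from compound 1 to compound 4 (beyond the scatter). Compound 4 is estimated at 30%, with a range from 10% to 55%.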

Compound 4, a percentage reported as inhibition, at one concentration (the size of the read-out at that concentration, not a potency): 80.2%
Compound 4: middle estimate off by 50.2 percentage points, on the low side; the measured number lies above the stated range.
By their numbers in this assay, from the lowest: compound 3; then compound 2; then compound 1; then compound 4.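

At this position on the aromatic ring, in this assay, putting (3-bromobenzyl)(ethyl)amino in place of diisopentylamino gives a number 33.2 percentage points higher from compound 1 to compound 4 (beyond the scatter) even though the heavy-atom count stays the same and an aromatic ring and a bromine enter. Compound 2 also carries a benzyl group on this amine nitrogen and gives 16.2% in this assay on its own, yet compound 4 shows that a benzyl group here can go with the highest number of the series, so such a group does not by itself bring a low number. Nothing measured here explains the rise.

The bromine, the benzyl ring and the ethyl chain all enter together, so the compounds shown leave open which of them carries the step. An ethyl amine with a plain benzyl group, or with chlorine in place of bromine, would help separate these parts.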